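A longer chain on the oxygen: compound 4

The source may report more compounds than this note shows. Statements on the series, on what has been measured and on what is new or still open speak of the compounds shown alone.

Three compounds share one core and differ only in the chain carried on the oxygen next to the carbonyl group. In an assay on HEK293 cells for displacement of a labelled ligand from Type-2 angiotensin II receptor (Homo sapiens), read by scintillation counting, with a stated time of 240 min (on this read-out higher numbers stand for weaker inhibition and lower numbers for stronger inhibition), compound 1 `COC(=O)NS(=O)(=O)c1sc(CC(C)C)cc1-c1cccc(Cn2ccnc2)c1` gives 400 nM, compound 2 `CCOC(=O)NS(=O)(=O)c1sc(CC(C)C)cc1-c1cccc(Cn2ccnc2)c1` gives 300 nM, and compound 3 `CC(C)Cc1cc(-c2cccc(Cn3ccnc3)c2)c(S(=O)(=O)NC(=O)OC(C)C)s1` gives 160 nM. Compound 3 has the lowest of the three numbers: one of the two steps leading to it, a 1.9-fold lower number from compound 2 to compound 3 (0.27 log units; within the scatter), stays within the scatter, while the other, a 2.5-fold lower number from compound 1 to compound 3 (0.40 log units; beyond the scatter), goes beyond it.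

Compound 4 `CCC(C)OC(=O)NS(=O)(=O)c1sc(CC(C)C)cc1-c1cccc(Cn2ccnc2)c1` carries the change (methyl in place of hydrogen on a saturated chain carbon, two bonds along the chain from an oxygen next to a carbonyl group). For the measured compounds named here, two measured steps bear on this: a 1.3-fold lower number from compound 1 to compound 2 (0.12 log units; within the scatter) and a 1.9-fold lower number from compound 2 to compound 3 (0.27 log units; within the scatter), each adding one methyl to the chain and each giving only a small lowering. A further methyl, placed one bond further out, is therefore expected to give at most a small lowering in this assay, or none beyond the scatter, as a 1.5-fold lower number from compound 3 to compound 4 (0.16 log units; within the scatter). Compound 4 is expected to give about 110 nM, most likely between 50 nM and 250 nM.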

Compound 4, inhibition constant: 440 nM
Beside the measured number, compound 4's estimate is 4.0-fold (0.60 log units) below it; the whole stated range lies below it.
By their numbers in this assay, from the lowest: compounds 3, 2, 1 and 4 (each within the scatter of the next, the first and the last beyond it).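

Going one carbon beyond isopropyl reverses the trend along this chain: sec-butyl gives a 2.8-fold higher number from compound 3 to compound 4 (0.44 log units; beyond the scatter) in this assay and so loses the advantage of isopropyl. Against the shorter chains, the steps are a 1.5-fold higher number from compound 2 to compound 4 (0.17 log units; within the scatter) and a 1.1-fold higher number from compound 1 to compound 4 (0.04 log units; within the scatter), so compound 4 sits level with both, and the lowering seen up to compound 3 does not extend to this longer branched chain. One added methyl therefore has no fixed effect here, and what it does depends on the chain that receives it: the same change on two cores in this assay, a 1.3-fold lower number (0.12 log units; within the scatter) from compound 1 to compound 2 and a 2.8-fold higher number (0.44 log units; beyond the scatter) from compound 3 to compound 4, 3.7-fold (0.56 log units) apart, beyond the scatter of two such steps.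

The compounds shown leave open whether the higher number goes with the greater length or with the particular branching of sec-butyl, a question that a straight butyl chain or a tert-butyl group on this oxygen could address. They also leave open how a ring such as cyclopentyl would read here.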